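Changing One Side Chain of Compound 3

The source may hold more compounds than are shown below. What is called first, only, known or untested is meant among the compounds shown, and "the series" means these compounds.

- compound 1 `N[C@@H](CCC(=O)OC[C@H]1O[C@@H](n2cc(F)c(=O)[nH]c2=O)C[C@@H]1OC(=O)CC[C@H](N)C(=O)O)C(=O)O` gives 0.292 h
- compound 2 `N[C@@H](CC(=O)OC[C@H]1O[C@@H](n2cc(F)c(=O)[nH]c2=O)C[C@@H]1O)C(=O)O` gives 0.273 h
- compound 3 `N[C@@H](CCC(=O)O[C@H]1C[C@H](n2cc(F)c(=O)[nH]c2=O)O[C@@H]1CO)C(=O)O` gives 0.17 h

In an ADME assay on tissue (MIA PaCa-2 cells, Homo sapiens) for pharmacokinetics (on this read-out lower numbers stand for a shorter-lived compound and higher numbers for a longer-lived compound), compound 3 gives 0.17 h and lies within the usual scatter of both compound 1 and compound 2. The next compound, compound 4 `CC(C)[C@H](N)C(=O)O[C@H]1C[C@H](n2cc(F)c(=O)[nH]c2=O)O[C@@H]1CO`, has 1-amino-2-methylpropyl in place of 3-amino-3-carboxypropyl on a carbonyl carbon. Within the data shown here, no measured compound carries 1-amino-2-methylpropyl, so the data offer no direct precedent for this change. The nearest evidence is a 1.7-fold lower number from compound 1 to compound 3 (0.23 log units; within the scatter), where hydrogen takes the place of (3-amino-3-carboxypropyl)carbonyl on an oxygen on a saturated carbon. That step is a different change, and it stays within the scatter, so it gives only weak guidance and points to no clear direction. No step beyond the scatter is therefore expected in this assay. The estimated step is a 1.6-fold higher number from compound 3 to compound 4 (0.22 log units; within the scatter) and remains uncertain. Compound 4 is expected to give about 0.28 h with an estimated range from 0.13 h to 0.9 h in repeat measurements.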

Compound 4, half-life: 0.203 h
Compound 4: middle estimate off by 1.4-fold (0.14 log units), on the high side, within the range that was stated.
By their numbers in this assay, from the lowest: compounds 3, 4, 2 and 1 (each within the scatter of the next).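

On a carbonyl carbon whose other neighbours are oxygen next to a carbonyl group, 1-amino-2-methylpropyl in place of 3-amino-3-carboxypropyl gives a 1.2-fold higher number from compound 3 to compound 4 (0.08 log units; within the scatter) in this assay for this side chain. Unlike the earlier step, which removed a whole side chain from an oxygen, this one exchanges one side chain for another at the same place. The entering group has 5 heavy atoms and no oxygen, the leaving group has 7 heavy atoms including 2 oxygens, and that exchange does not take the read-out beyond the usual scatter. No measurement here offers a reason for the size of this step. The compounds shown leave open how a longer chain ending in an amine, or a plain isopropyl group with no amine, would read on this same carbonyl carbon.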